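Pyrimidin-2-yl on the ring nitrogen of compound 3

The source may hold more compounds than are shown below. What is called first, only, known or untested is meant among the compounds shown, and "the series" means these compounds.

In an in vitro ADME assay on microsomes from liver (Mus musculus) for pharmacokinetics, read by LC-MS, with a stated time of 10 min, tested at 1 uM (on this read-out lower numbers stand for slow clearance and higher numbers for fast clearance), compound 1 (`COc1ccc(NC(=O)[C@H]2CN(C)C[C@@H]2c2ccc(/C=C/C(=O)Nc3ccccc3N)cc2)cc1`) gives 54 mL/min/kg, compound 2 (`CN1C[C@H](C(=O)N2CCCCC2)[C@@H](c2ccc(/C=C/C(=O)Nc3ccccc3N)cc2)C1`) gives 42 mL/min/kg and compound 3 (`CC(C)(C)N1C[C@H](C(=O)Nc2ccc(Cl)cc2)[C@@H](c2ccc(/C=C/C(=O)Nc3ccccc3N)cc2)C1`) gives 20 mL/min/kg. Compound 3 is the lowest of the three, and its gap to each of the others lies beyond the scatter.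

Compound 4 (`Nc1ccccc1NC(=O)/C=C/c1ccc([C@H]2CN(c3ncccn3)C[C@@H]2C(=O)Nc2ccc(Cl)cc2)cc1`) keeps the (4-chlorophenyl)carbamoyl group of compound 3 but has pyrimidin-2-yl in place of tert-butyl on an amine nitrogen in a ring.

Going by the values given here, the only measured step in one place, a 1.3-fold lower number from compound 1 to compound 2 (0.11 log units; within the scatter), lies within the scatter. It concerns a carbonyl carbon, not this nitrogen, so it gives little guidance here. Among the compounds with values here, no measured step isolates a change on the nitrogen. Compound 1 and compound 2 both carry methyl there, but each also differs from compound 3 elsewhere, so their higher values cannot be assigned to the nitrogen alone.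

Within the data shown here, with compound 3 at 20 mL/min/kg, the lowest value so far, a small upward step in this assay is expected, though not one confidently beyond the scatter. The estimated step is a 1.4-fold higher number from compound 3 to compound 4 (0.15 log units; within the scatter). The estimated clearance for compound 4 is 28 mL/min/kg, with an expected range of 13 mL/min/kg to 55 mL/min/kg.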

Compound 4, clearance: 44 mL/min/kg
Compound 4: the middle estimate sits 1.6-fold (0.20 log units) below what was measured, within the range that was stated.
By their numbers in this assay, from the lowest: compound 3; then compounds 2, 4 and 1 (each within the scatter of the next).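

In this assay, pyrimidin-2-yl in place of tert-butyl on the amine nitrogen in the ring gives a 2.2-fold higher number from compound 3 to compound 4 (0.34 log units; beyond the scatter) toward faster clearance, with the (4-chlorophenyl)carbamoyl group unchanged. Going by these compounds alone, this is the first step isolated at this nitrogen, and it shows that the read-out can respond to a change here, whereas the only earlier one-place step, a 1.3-fold lower number from compound 1 to compound 2 (0.11 log units; within the scatter) on a carbonyl carbon, gave no separation from the scatter. The change removes a group with no ring and brings in a six-membered aromatic ring with 2 hetero atoms, but no measurement is available to explain the step or connect it to either feature.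

The result does not separate the departure of tert-butyl from the arrival of pyrimidin-2-yl, and a methyl or a plain phenyl on this nitrogen, with the (4-chlorophenyl)carbamoyl group kept, would help to divide the two. It also leaves open whether the same exchange on the nitrogen would give a step of similar size with piperidin-1-yl on the carbonyl carbon, where the amide partner is no longer an aromatic amine.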